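A few compounds are considered here, and "the series" means these few. Any claim that something is new, unique, unknown or untested is made for them only; others in the source may bear on it.

Measured so far:
compound 1, `O=c1cc(CSC(=S)N2CCCCC2)oc2cc(Cl)ccc12` — 1600 nM
compound 2, `O=c1cc(CSC(=S)N2CCCCC2)oc2ccccc12` — 12000 nM

Both were run in a functional assay on HEp-2 cells (Homo sapiens) for antiproliferative activity, read by MTT assay, with a stated time of 72 h; on this read-out higher numbers stand for weaker inhibition and lower numbers for stronger inhibition. Within the data shown here, compound 1 has the lowest of the two numbers; the one measured step, a 7.5-fold higher number from compound 1 to compound 2 (0.88 log units; beyond the scatter), separates it from compound 2 and is the only internal reference in this assay.

Compound 3, `CCN(CC)C(=S)SCc1cc(=O)c2ccc(Cl)cc2o1`, has not yet been measured. It differs from compound 1 in one place: diethylamino in place of piperidin-1-yl on a thiocarbonyl carbon. Among the measured compounds shown here, the measured step concerns the aromatic part of the shared core, not the thiocarbonyl carbon, so no measured step bears on this exchange. With nothing in the data to argue for either direction, the step of a 1.3-fold higher number from compound 1 to compound 3 (0.10 log units; within the scatter) is expected to stay within the usual scatter. Compound 3 is therefore estimated at 2000 nM in this assay, with a range from 700 nM to 6000 nM, the width reflecting the absence of a comparable measured step rather than any expected trend.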

Compound 3, half-maximal inhibitory concentration: 8800 nM
Beside the measured number, compound 3's estimate is 4.4-fold (0.64 log units) below it; measured number above the stated range.
By their numbers in this assay, from the lowest: compound 1; then compounds 3 and 2 (each within the scatter of the next).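

In this assay the thiocarbonyl carbon is a sensitive place in this series: the exchange of piperidin-1-yl for diethylamino, which has no ring, gives a 5.5-fold higher number from compound 1 to compound 3 (0.74 log units; beyond the scatter) on this read-out. With a 7.5-fold higher number from compound 1 to compound 2 (0.88 log units; beyond the scatter) as the other measured step, single changes at two separate places have now moved the number beyond the scatter, each time upward from compound 1. Among these compounds, nothing measured so far gives a reason for the higher number of compound 3.

Pyrrolidin-1-yl, morpholin-4-yl or dimethylamino on the same thiocarbonyl carbon would show whether the ring itself, its size or its atoms go with the lower number. Diethylamino paired with hydrogen in place of chloro on the aromatic carbon would show whether the two steps add up.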